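Benzyl ether diamine series: methoxy to ethoxy on benzyl ring

The source may report more compounds than this note shows. Statements on the series, on what has been measured and on what is new or still open speak of the compounds shown alone.

Measured so far:
- compound 1 `COc1cccc(OC)c1OCCNCCOc1ccccc1OCc1ccccc1Cl`: 5400 nM
- compound 2 `COc1ccc(COc2ccccc2OCCNCCOc2c(OC)cccc2OC)cc1`: 8500 nM

Both numbers come from a functional assay on PC-3 cells (Homo sapiens) for cytotoxicity, read by sulforhodamine B assay; on this read-out higher numbers stand for weaker inhibition of growth and lower numbers for stronger inhibition of growth; in that assay compound 1 gives 5400 nM and compound 2 gives 8500 nM. Among the compounds with values here, compound 2 stands at the higher of the two numbers, but the only step between measured compounds, a 1.6-fold higher number from compound 1 to compound 2 (0.20 log units; within the scatter), is within the scatter, so the two compounds cannot be ordered on these data.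

Compound 3 `CCOc1ccc(COc2ccccc2OCCNCCOc2c(OC)cccc2OC)cc1` is not yet measured. It differs from compound 2 by methyl in place of hydrogen on a saturated chain carbon bound to an oxygen on an aromatic ring. Within the data shown here, no measured step touches this change: the one step known, a 1.6-fold higher number from compound 1 to compound 2 (0.20 log units; within the scatter), swaps the whole benzyl aryl group and still moves the number by less than the scatter, so nothing so far points to a direction for a smaller change at the same place. The expectation for this assay is therefore no step beyond the scatter, and the estimated step of no change at the digits printed from compound 2 to compound 3 (within the scatter) reflects that.

Compound 3 is estimated at 8500 nM, with a range from 3500 nM to 20000 nM.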

Compound 3, concentration for 50% growth inhibition: 5200 nM
Compound 3: middle estimate off by 1.6-fold (0.21 log units), on the high side; the range from low to high includes it.
By their numbers in this assay, from the lowest: compounds 3, 1 and 2 (each within the scatter of the next).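

In this assay, extending methoxy to ethoxy on the 4-methoxyphenyl group gives a 1.6-fold lower number from compound 2 to compound 3 (0.21 log units; within the scatter), so this first change at the chain carbon bound to an oxygen on an aromatic ring has no effect that can be told apart from the scatter. The 4-ethoxyphenyl group in place of 2-chlorophenyl gives a 1.0-fold lower number from compound 1 to compound 3 (0.02 log units; within the scatter), and together with the earlier step this means that the three aryl groups now shown, one chlorine-bearing and two alkoxy-bearing, cannot be separated in this assay, so the series gives no order among compounds 1, 2 and 3. No evidence accompanies these numbers that could explain this flat picture.

As far as these compounds go, whether a longer chain such as butoxy, or a group of another kind such as an amine or a carboxylic acid, at this place would move the number beyond the scatter remains open. The compounds shown also vary only this one part of the shared core, so whether the number responds to changes elsewhere in the core is equally open.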